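Thioether variant of a dichlorophenoxy quinoxaline-type diamine

The compounds below may be only part of what the source reports. "The series", "measured", "known", "first", "only" and "open" are said of these compounds alone.

Measured compounds:
compound 1, `Nc1cc(N)c2nc(-c3ccccc3)c(Oc3ccc(Cl)c(Cl)c3)nc2c1`, < 100000 nM;
compound 2, `COc1ccc(Sc2nc3cc(N)cc(N)c3nc2-c2ccccc2)cc1`, < 100000 nM.

In a functional assay on NCI-H322M cells (Homo sapiens) for inhibition, read by sulforhodamine B assay, with a stated time of 48 h (on this read-out lower numbers stand for higher toxicity in this test and higher numbers for lower toxicity in this test), compound 1 gives < 100000 nM, which is a limit of the assay and not a number. Compound 2 likewise gives only a limit, < 100000 nM. Among the measured compounds shown here, the one measured step, a step that the two limits leave unreadable from compound 1 to compound 2, therefore cannot be read, and the whole of what is known is that (the limit of < 100000 nM in this assay, at which 2 of the 2 values shown sit).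

Compound 3, `Nc1cc(N)c2nc(-c3ccccc3)c(Sc3ccc(Cl)c(Cl)c3)nc2c1`, is not yet measured. It differs from compound 2 by 3,4-dichlorophenyl in place of 4-methoxyphenyl on a sulfur. For the measured compounds named here, since compound 2 stands only at a limit and the single measured step is unreadable, no size or direction can be drawn from the data for this change. Compound 3 is therefore expected to stay in the same region as compound 2, with the step that the limit leaves unreadable from compound 2 to compound 3 expected to be small. The estimate for compound 3 is 20000 nM, between 2000 nM and 100000 nM, most likely again reported only as a limit.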

Compound 3, concentration lethal to 50% of the cells: < 100000 nM
Compound 3 was reported as a limit (the forecaster's own chance of this, stated with the estimate: 70%); the middle value does not contradict the limit.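

In this assay compound 3 gives < 100000 nM, again a limit and not a number. Its steps from compound 1 and from compound 2 therefore cannot be read: the limit of < 100000 nM in this assay, at which 3 of the 3 values shown sit.

The compounds shown leave open whether compound 1, compound 2 and compound 3 differ at all in this test, and by how much.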